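Compound 3 and one more methoxy

This account rests on a few compounds, and the source may have more. Where it says the series, first, only, none or still open, it means among the compounds named here.

Measured in a functional assay on MDA-MB-231 cells (Homo sapiens) for antiproliferative activity, read by MTT assay, with a stated time of 48 h; a higher number here means a weaker inhibitor of growth, a lower number a stronger inhibitor of growth:
compound 1 `COC(=O)N1N=C(c2ccccc2)CC1c1ccc(OC)c(O)c1` gives 14500 nM
compound 2 `COC(=O)N1N=C(c2ccccc2)CC1c1ccc(OC)cc1` gives > 10000 nM, which is a limit of the assay and not a number
compound 3 `COC(=O)N1N=C(c2ccccc2)CC1c1ccc(OC)c(OC)c1` gives 8940 nM

Among the compounds with values here, compound 3 holds one of only two actual numbers in this small set, and the other belongs to compound 1. The two are not separated: a 1.6-fold lower number from compound 1 to compound 3 (0.21 log units; within the scatter).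

Compound 4 `COC(=O)N1N=C(c2ccccc2)CC1c1cc(OC)c(OC)cc1OC` differs from compound 3 by one change: methoxy in place of hydrogen on an aromatic carbon. In words, this is methoxy in place of hydrogen on an aromatic carbon.

The closest measured precedent is the same kind of change on another aromatic carbon, an at least 1.1-fold lower number from compound 2 to compound 3 (0.04 log units; that floor lies within the scatter). This gives only a floor for that step, and the floor shows no shift beyond the scatter. The step that the limit leaves unreadable from compound 1 to compound 2 offers no size to work from. On this evidence, no step beyond the scatter is expected in this assay, and the expected change is a 1.0-fold higher number from compound 3 to compound 4 (0.00 log units; within the scatter).

Compound 4 could also end at the limit of > 10000 nM in this assay, at which 1 of the 3 values shown sits. The estimated value for compound 4 is 9000 nM, with an expected range from 3500 nM to 25000 nM.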

Compound 4, concentration for 50% growth inhibition: > 10000 nM
Compound 4 was reported as a limit; the forecaster's own chance of this, stated with the estimate: 30%; middle value at least 1.1-fold (0.04 log units) away from the limit.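

At this position, on an aromatic carbon ortho to a large group, methoxy in place of hydrogen gives in this assay an at least 1.1-fold higher number from compound 3 to compound 4 (0.04 log units; that floor lies within the scatter). That floor shows no shift beyond the scatter, and how far the true step runs cannot be read. So this further methoxy shows only that the change gave no number clear of the one compound 3 gives, 8940 nM. The value of compound 4 is a limit and not a number, which leaves the set with a second compound at that limit: the limit of > 10000 nM in this assay, at which 2 of the 4 values shown sit.

The compounds shown leave open whether an amine or a carboxylic acid on this same aromatic carbon would give a number clear of the limit in this assay. They also leave open whether a longer chain, such as ethoxy in place of the new methoxy, would give the same reading, and whether a smaller atom such as fluorine would do so at this position.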